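Imidazolyl sulfanyl in place of benzothiazolyl sulfanyl on the acetamide

The compounds below may be only part of what the source reports. "The series", "measured", "known", "first", "only" and "open" are said of these compounds alone.

Compound 1 `Cn1c(-c2ccc(NC(=O)CCl)cc2)nc(-c2ccccc2)c1-c1ccccc1` gives 42.8% in a functional assay on MCF7 cells (Homo sapiens) for cytotoxicity, read by MTT assay, with a stated time of 24 h, tested at 32 ug/mL; on this read-out higher numbers stand for a stronger effect at the one concentration tested and lower numbers for a weaker effect. Compound 2 `Cn1c(-c2ccc(NC(=O)CSc3nc4cc(Cl)ccc4o3)cc2)nc(-c2ccccc2)c1-c1ccccc1` gives 59.7%, and compound 3 `Cn1c(-c2ccc(NC(=O)CSc3nc4ccccc4s3)cc2)nc(-c2ccccc2)c1-c1ccccc1` gives 59%. On these three numbers compound 3 stands second highest, with compound 2 a number 0.7 percentage points lower from compound 2 to compound 3 (within the scatter) and compound 1 a number 16.2 percentage points higher from compound 1 to compound 3 (beyond the scatter). Compound 4 `Cn1ccnc1SCC(=O)Nc1ccc(-c2nc(-c3ccccc3)c(-c3ccccc3)n2C)cc1` is not yet measured; it differs from compound 3 by 1-methyl-1H-imidazol-2-yl in place of 1,3-benzothiazol-2-yl on a sulfur.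

The bearing steps are a number 16.9 percentage points higher from compound 1 to compound 2 (beyond the scatter) and a number 16.2 percentage points higher from compound 1 to compound 3 (beyond the scatter), both modest gains on moving from chloro to an aryl sulfanyl group, and a number 0.7 percentage points lower from compound 2 to compound 3 (within the scatter), which shows that exchanging one such aryl group for another changed nothing beyond the scatter. Within the data shown here, no measured step removes the six-membered aromatic ring of carbon only while keeping a sulfanyl-linked five-membered aromatic ring with 2 hetero atoms, so compound 4 may sit anywhere between the chloro level of compound 1 and the level of compound 3. The expected step is a number 7 percentage points lower from compound 3 to compound 4 (within the scatter), a small loss that may well fall within the scatter. Compound 4 is therefore estimated at 52%, with a range from 38% to 66%.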

Compound 4, a percentage reported as activity, at one concentration (the size of the read-out at that concentration, not a potency): 43.4%
For compound 4 the middle estimate is 8.6 percentage points above the measured one; the range from low to high includes it.
By their numbers in this assay, from the lowest: compounds 1 and 4 (each within the scatter of the next); then compounds 3 and 2 (each within the scatter of the next).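

In this assay the sulfur does not accept every ring alike: a number 15.6 percentage points lower from compound 3 to compound 4 (beyond the scatter) and a number 16.3 percentage points lower from compound 2 to compound 4 (beyond the scatter) while the exchange of 5-chloro-1,3-benzoxazol-2-yl for 1,3-benzothiazol-2-yl stayed within the scatter. With 1-methyl-1H-imidazol-2-yl on the sulfur, the gain over chloro is gone, with a number 0.6 percentage points higher from compound 1 to compound 4 (within the scatter) as the step, so the sulfanyl link alone does not carry the level of compound 2 and compound 3, which each hold a six-membered aromatic ring of carbon only where compound 4 has none. Nothing measured here gives a reason for this drop.

As far as these compounds go, the loss of that ring and the arrival of the methyl of 1-methyl-1H-imidazol-2-yl come together in compound 4, so their shares stay open. Also open, from the compounds shown here alone, is how a phenyl on the sulfur, or a morpholine in place of the whole sulfanyl group, would read here.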